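Replacing a Ring-Bearing Carbonyl Group with a Methoxyethyl Chain

The source may report more compounds than this note shows. Statements on the series, on what has been measured and on what is new or still open speak of the compounds shown alone.

Three compounds have been measured in a functional assay on HeLa cells (Homo sapiens) for cytotoxicity, read by MTT assay; on this read-out higher numbers stand for weaker inhibition and lower numbers for stronger inhibition:
Compound 1 `CC(=O)OCCC(=O)O[C@H](CC=C(C)C)C1=CC(=O)c2c(O)ccc(O)c2C1=O` gives 17300 nM.
Compound 2 `CC(C)=CC[C@@H](OC(=O)CC(C)(O)c1ccccc1)C1=CC(=O)c2c(O)ccc(O)c2C1=O` gives 85700 nM.
Compound 3 `CC(C)=CC[C@@H](OC(=O)C1CCCO1)C1=CC(=O)c2c(O)ccc(O)c2C1=O` gives 17000 nM.

Compound 3 holds the lowest number of the three, yet its gap to compound 1 is small: a 1.0-fold lower number from compound 1 to compound 3 (0.01 log units; within the scatter). Only compound 2 stands clearly apart, as a 5.0-fold lower number from compound 2 to compound 3 (0.70 log units; beyond the scatter) shows. Compound 4 `COCCO[C@H](CC=C(C)C)C1=CC(=O)c2c(O)ccc(O)c2C1=O` differs from compound 3 in a single place: 2-methoxyethyl in place of (oxolan-2-yl)carbonyl on an oxygen on a saturated carbon. A carbonyl and a five-membered ring leave, and a short chain with one oxygen enters.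

Which measured steps bear on this? a 1.0-fold lower number from compound 1 to compound 3 (0.01 log units; within the scatter) shows that swapping one group on the carbonyl carbon for another leaves the number unchanged, while a 5.0-fold higher number from compound 1 to compound 2 (0.69 log units; beyond the scatter) shows that a bulkier replacement in that region raises it modestly. Within the data shown here, none of the measured steps removes the carbonyl itself, so the evidence is indirect. A small step, within the scatter or slightly beyond it, is expected, with no firm direction. Compound 4 is therefore estimated at 20000 nM, in the range 8000 nM to 50000 nM, which amounts to an expected step of a 1.2-fold higher number from compound 3 to compound 4 (0.07 log units; within the scatter).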

Compound 4, half-maximal inhibitory concentration: 62400 nM
Beside the measured number, compound 4's estimate is 3.1-fold (0.49 log units) below it; the measured number lies above the stated range.
By their numbers in this assay, from the lowest: compounds 3 and 1 (each within the scatter of the next); then compounds 4 and 2 (each within the scatter of the next).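

In this assay, among these compounds, the earlier compounds varied only what sits on the carbonyl carbon, and all of them kept that carbonyl. Here the whole acyl group gives way to 2-methoxyethyl, and the number rises by nearly the same size against both partners: a 3.7-fold higher number from compound 3 to compound 4 (0.56 log units; beyond the scatter) and a 3.6-fold higher number from compound 1 to compound 4 (0.56 log units; beyond the scatter) on this oxygen. Compound 1 carries no ring in this group, so the rise does not depend on losing the ring of compound 3, but no measurement at hand explains the step.

The compounds shown do not separate losing the carbonyl from changing the chain that comes with it. Also open, going by these compounds, is how an acetyl group, a 2-aminoethyl group or a longer ether such as 3-methoxypropyl would read on this oxygen.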